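A few compounds are considered here, and "the series" means these few. Any claim that something is new, unique, unknown or untested is made for them only; others in the source may bear on it.

Measured in a physicochemical assay for solubility, read by nephelometry, in phosphate buffer, at pH 6.5; on this read-out lower numbers stand for lower solubility and higher numbers for higher solubility:
- Compound 1 `N#Cc1cnc(NC(=O)CCCOc2ccccc2)s1`: 1100 nM
- Compound 2 `CC(C)c1cnc(NC(=O)CCCOc2ccccc2)s1`: < 1200 nM (a limit, not a number)

Compound 2 has no exact position on the scale of this assay. All that exists for it is the limit of < 1200 nM in this assay, at which 1 of the 2 values shown sits.

The next compound, compound 3 `Cc1cnc(NC(=O)CCCOc2ccccc2)s1`, keeps the rest of compound 2 unchanged and differs in one place: methyl in place of isopropyl on an aromatic carbon. The group that changes therefore stays on the same aromatic carbon, and only its size differs.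

For the measured compounds named here, one measured step bears on this change, the replacement at that same carbon in a step that the limit leaves unreadable from compound 1 to compound 2. Its size cannot be read, so it offers no measured guide to how far a swap at this carbon moves the read-out, or in which direction. Going by the values given here, the only exact value nearby is that of compound 1, at 1100 nM, so the expectation is anchored there, with no shift beyond the usual scatter of the assay and no favoured direction.

The estimated change is a number no lower from compound 2 to compound 3 (the limit leaves the size open), which can only be a loose figure given the limit it starts from. For compound 3 the expected value is 1200 nM, with an estimated range from 500 nM to 5000 nM.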

Compound 3, solubility: < 1100 nM
Compound 3 gave a limit, no number (the forecaster's own chance of this, stated with the estimate: 45%); middle value at least 1.0-fold (0.03 log units) from the limit.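

In this assay compound 3 gives < 1100 nM, which is a limit and not a number. Of the three groups shown on this aromatic carbon, only the cyano group of compound 1 gives an exact value, 1100 nM. Methyl in place of cyano on this carbon gives a number no higher from compound 1 to compound 3 (the limit leaves the size open). The step from compound 2 to compound 3 cannot be read, so replacing isopropyl with methyl has no measured size or direction.

Where compound 2 and compound 3 actually sit on this scale remains open, as does whether they differ from each other or from compound 1. Also open, as far as these compounds go, is what an amine or a carboxylic acid on this same carbon would give in this assay.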